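Swapping the Amine Substituent of Compound 1

A few compounds are considered here, and "the series" means these few. Any claim that something is new, unique, unknown or untested is made for them only; others in the source may bear on it.

Compound 1 `O=C(Nc1cccc(OC(F)(F)F)c1)NC1CCN(C/C2=C/CCCCCC2)CC1` belongs to a small set of urea-linked piperidines tested for their ability to block the receptor in a functional assay on CHO cells for antagonist activity at C-X-C chemokine receptor type 3 (Homo sapiens), read by GTPgammaS binding (a higher number here means a weaker inhibitor, a lower number a stronger inhibitor), where compound 1 gives 104 nM. Among the three measured compounds it stands second highest: its nearest neighbour is compound 3 `CC1(C)[C@H]2CC=C(CN3CCC(NC(=O)Nc4cc(C(F)(F)F)cc(C(F)(F)F)c4)CC3)[C@@H]1C2`, which gives 73 nM, a gap that lies within the scatter, while the furthest is compound 2 `COC(=O)c1cccc(NC(=O)NC2CCN(C/C3=C/CCCCCC3)CC2)c1`, which gives 660 nM. Among the measured compounds shown here, the one measured step, a 6.3-fold higher number from compound 1 to compound 2 (0.80 log units; beyond the scatter), concerns the aromatic side of the urea and not the amine side.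

The new compound 4 `CC1(C)[C@H]2CC=C(CN3CCC(NC(=O)Nc4cccc(OC(F)(F)F)c4)CC3)[C@@H]1C2` differs from compound 1 only on the amine side: a group of 9 heavy atoms (9 carbon; one four-membered non-aromatic ring of carbon only, one six-membered non-aromatic ring of carbon only) in place of a group of 8 heavy atoms (8 carbon; one eight-membered non-aromatic ring of carbon only), on a saturated chain carbon bound to an amine nitrogen in a ring. For the measured compounds named here, no measured step follows this exact change. What bears on it is that compound 3 already carries the entering group and lands within the scatter of compound 1, though compound 3 also differs on the aromatic side, so the comparison is indirect. Compound 4 is therefore expected to show a step of a 1.2-fold lower number from compound 1 to compound 4 (0.09 log units; within the scatter) in this assay, that is, no shift beyond the scatter. The estimate for compound 4 is 85 nM, with a range from 30 nM to 250 nM.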

Compound 4, inhibition constant: 31 nM
For compound 4 the middle estimate is 2.7-fold (0.44 log units) above the measured one, and the stated range covers the measured number.
By their numbers in this assay, from the lowest: compound 4; then compounds 3 and 1 (each within the scatter of the next); then compound 2.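

Among the compounds shown here, with the aromatic side held constant, compound 4 gives the first direct reading of the amine side: in this assay, exchanging cyclooct-1-en-1-yl for the group holding a four-membered and a six-membered carbon ring produces a 3.4-fold lower number from compound 1 to compound 4 (0.53 log units; beyond the scatter). The earlier step, a 6.3-fold higher number from compound 1 to compound 2 (0.80 log units; beyond the scatter), showed only that the aromatic side matters, whereas this one shows that the number also responds to the group on the saturated chain carbon bound to the ring amine nitrogen, even though both groups count one double bond outside aromatic rings, no hydrogen-bond donors or acceptors and no net charge. No accompanying measurement bears on why this exchange lowers the number.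

The compounds shown leave open whether the same step would appear with another aromatic side, such as the two trifluoromethyl groups of compound 3, since no partner of compound 3 carrying cyclooct-1-en-1-yl is shown. They also leave open how the number would respond to the opposite arrangement at the two defined stereocentres, or to a simpler cyclohexyl group or a ring carrying an amine or a carboxylic acid at this place.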